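The source may hold more compounds than are shown below. What is called first, only, known or untested is meant among the compounds shown, and "the series" means these compounds.

Compound 2 `CSCc1ccc(-c2cnc(C(=O)CCCCCCc3ccccc3)o2)nc1` gives 11.1 nM in an assay for inhibition of Fatty-acid amide hydrolase 1 (Rattus norvegicus), using a Dixon plot (a higher number here means a weaker inhibitor, a lower number a stronger inhibitor), the higher of the two numbers recorded so far, while compound 1 `O=C(CCCCCCc1ccccc1)c1ncc(-c2ccc(CO)cn2)o1` gives 3.2 nM. Within the data shown here, the one measured step, a 3.5-fold higher number from compound 1 to compound 2 (0.54 log units; beyond the scatter), concerns only the exchange of a small group on a saturated chain carbon bound to an aromatic carbon. Compound 3 `COC(=O)CCCCc1cnc(C(=O)CCCCCCc2ccccc2)o1` has not yet been measured. It differs from compound 2 by a group of 8 heavy atoms (6 carbon, 2 oxygen; no ring) in place of a group of 9 heavy atoms (7 carbon, 1 nitrogen, 1 sulfur; one six-membered aromatic ring with 1 hetero atom), on an aromatic carbon: the six-membered aromatic ring with its attached group is gone, and a 4-(methoxycarbonyl)butyl chain stands in its place. Among the measured compounds shown here, no measured step touches this part of the molecule; the step from compound 1 to compound 2 is a swap within the same ring substituent and is modest in size, so it offers little guidance for removing the ring altogether. Because the present change is far larger than a 3.5-fold higher number from compound 1 to compound 2 (0.54 log units; beyond the scatter), a shift beyond the scatter is expected, most likely toward a higher number, though with wide uncertainty. Compound 3 is therefore expected to give about 60 nM in this assay, between 10 nM and 400 nM, which would amount to a 5.4-fold higher number from compound 2 to compound 3 (0.73 log units; beyond the scatter).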

Compound 3, inhibition constant: 1.8 nM
For compound 3 the middle estimate is 33-fold (1.52 log units) above the measured one, and the stated range ends above it.
By their numbers in this assay, from the lowest: compounds 3 and 1 (each within the scatter of the next); then compound 2.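

On an aromatic carbon of the five-membered aromatic ring, next to the ring oxygen, the earlier compounds had shown only a change within the ring substituent; here the six-membered aromatic ring itself goes, and 4-(methoxycarbonyl)butyl in its place gives a 6.2-fold lower number from compound 2 to compound 3 (0.79 log units; beyond the scatter) in this assay, so in this series that ring is not needed for a low number. The comparison with the hydroxymethyl group gives a 1.8-fold lower number from compound 1 to compound 3 (0.25 log units; within the scatter), which means that 5-(hydroxymethyl)pyridin-2-yl and the open chain cannot be told apart in this assay, and that the step from the group in compound 2 cannot be credited to the loss of the ring alone, as the methylsulfanyl group leaves with it. Nothing available accounts for these numbers.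

Still open, going by these compounds, is whether the methyl ester at the chain end matters at all, which a carboxylic acid or a plain pentyl chain at this place would test. Open too, on these data alone, is how far the chain length can move, in either a shorter or a longer chain, with the number staying where it is.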